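Chloro in place of trifluoromethyl: outlook for compound 3

A few compounds are considered here, and "the series" means these few. Any claim that something is new, unique, unknown or untested is made for them only; others in the source may bear on it.

Compound 2 `CCN(c1ccc(C#N)c(C(F)(F)F)c1)c1cc(-n2ccnc2)ccc1C` is tested in a functional assay on VCaP cells (Homo sapiens) for antiproliferative activity, read by CCK-8 assay, with a stated time of 6 days; a higher number here means a weaker inhibitor, a lower number a stronger inhibitor. In this assay compound 2 gives >= 3920 nM, which is a limit of the assay and not a number. Compound 1 `CCN(c1ccc(C#N)c(Cl)c1)c1cc(-c2ccccc2)ccc1C` gives > 30000 nM in this assay, also a limit. Compound 2 thus stands at the limit of >= 3920 nM in this assay, at which 1 of the 2 values shown sits. Compound 1 stands at the limit of > 30000 nM in this assay, at which 1 of the 2 values shown sits. Compound 3 `CCN(c1ccc(C#N)c(Cl)c1)c1cc(-n2ccnc2)ccc1C` differs from compound 2 by chloro in place of trifluoromethyl on an aromatic carbon. Among the compounds with values here, no measured step separates any two compounds here, so a step within the usual scatter, or none at all, is expected. Compound 3 is expected to give 10000 nM in this assay, between 3000 nM and 30000 nM. The expected step is a step that the limit leaves unreadable from compound 2 to compound 3.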

Compound 3, half-maximal inhibitory concentration: > 30000 nM
Compound 3: no number, only a limit (the forecaster's own chance of this, stated with the estimate: 70%); at least 3.0-fold (0.47 log units) between middle value and limit.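

In this assay, within the data shown here, compound 1, compound 2 and compound 3 all stand at limits of the assay, and no step among them can be read. Left open is how far chloro and trifluoromethyl, or phenyl and 1H-imidazol-1-yl, differ in antiproliferative activity.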